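Microsomal stability across an amide series: step to compound 4

This account rests on a few compounds, and the source may have more. Where it says the series, first, only, none or still open, it means among the compounds named here.

Measured so far in an ADME assay on microsomes from liver (Homo sapiens) for metabolic stability, read by LC-MS, with a stated time of 30 min, tested at 1 uM; a lower number here means that less of the compound is left, a higher number that more of the compound is left:
compound 1 `O=C(NCc1ccc(S(=O)(=O)c2ccccc2)cc1)c1cc2ncccc2s1` gives 81%
compound 2 `Cn1c(C(=O)NCc2ccc(S(=O)(=O)c3ccccc3)cc2)cc2ccncc21` gives 71%
compound 3 `O=C(NCc1ccc(S(=O)(=O)c2ccccc2C(F)(F)F)cc1)c1cc2cnccc2[nH]1` gives 52%

Compound 1 holds the highest number of the three. Against compound 2 the gap lies within the usual scatter, so no order between these two can be claimed; against compound 3 the gap lies beyond the scatter, and compound 3 stands clearly lower.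

Compound 4 `O=C(NCc1ccc(S(=O)(=O)c2ccccc2)cc1)c1ccc2nccn2c1` has not yet been measured. It differs from compound 1 in one place: a group of 9 heavy atoms (7 carbon, 2 nitrogen; one five-membered aromatic ring with 2 hetero atoms, one six-membered aromatic ring with 1 hetero atom) in place of a group of 9 heavy atoms (7 carbon, 1 nitrogen, 1 sulfur; one five-membered aromatic ring with 1 hetero atom, one six-membered aromatic ring with 1 hetero atom), on a carbonyl carbon. The shared core, the sulfonyl-bearing side and the amide linkage are kept.

Among the compounds with values here, no step between two measured compounds covers a change of this kind, so there is no directly comparable step to lean on. The three measured numbers span a band from the value of compound 3 up to that of compound 1, and a swap of one fused aromatic group for another of equal size is taken here to move the read-out, if at all, by a small amount downward or not beyond the scatter. Compound 4 is therefore expected at 72%, within a range from 52% to 88%. The expected step of a number 9 percentage points lower from compound 1 to compound 4 (within the scatter) is estimated to stay within the scatter.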

Compound 4, percent of the compound remaining: 77%
Compound 4: middle estimate off by 5 percentage points, on the low side; low and high end bracket the measured number.
By their numbers in this assay, from the lowest: compound 3; then compounds 2, 4 and 1 (each within the scatter of the next).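

In this assay, the swap on the carbonyl carbon gives a number 4 percentage points lower from compound 1 to compound 4 (within the scatter), so no order can be claimed between the two compounds. Within the data shown here, this is the first step that can be read at this position, since the earlier compounds offered no pair differing in one place. At this place, the group of 9 heavy atoms holding sulfur gives way to the group of 9 heavy atoms with 7 carbon and 2 nitrogen, and the read-out shows no change beyond the scatter, so sulfur in the fused group is not needed to hold the number in this range.

Still open, from the compounds shown here alone, is whether a carboxylic acid or a primary amine on the fused group, or a plain phenyl ring in its place, would hold the number as well. The measurements shown offer no reason for this outcome.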